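The source may report more compounds than this note shows. Statements on the series, on what has been measured and on what is new or still open speak of the compounds shown alone.

Measured so far in an ADME assay on SW480 cells (Homo sapiens) for cytotoxicity, read by MTT assay, with a stated time of 72 h; on this read-out higher numbers stand for weaker inhibition and lower numbers for stronger inhibition: compound 1 `O=C(Nc1ccccc1)c1cccc(/C=C2\CC(=O)N(c3ccccc3)C2=O)c1`, compound 2 `Cc1ccc(NC(=O)c2cccc(/C=C3\CC(=O)N(c4ccccc4)C3=O)c2)cc1C`, compound 3 `COc1ccc(OC)c(NC(=O)c2cccc(/C=C3\CC(=O)N(c4ccccc4)C3=O)c2)c1`.

In this assay compound 1 gives > 100000 nM, which is a limit of the assay. Compound 2 gives > 100000 nM, also a limit. Compound 3 gives > 100000 nM, again a limit. All three values sit at the limit of > 100000 nM in this assay, at which 3 of the 3 values shown sit, so the steps a step that the two limits leave unreadable from compound 1 to compound 2, a step that the two limits leave unreadable from compound 1 to compound 3 and a step that the two limits leave unreadable from compound 2 to compound 3 carry no readable size; compound 3 stands where the other two stand, at the limit.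

Compound 4 `O=C(Nc1ccc(Cl)cc1)c1cccc(/C=C2\CC(=O)N(c3ccccc3)C2=O)c1` differs from compound 3 on the amide-type nitrogen: 4-chlorophenyl in place of 2,5-dimethoxyphenyl on an amide-type nitrogen. Going by the values given here, none of the measured steps involves a 4-chlorophenyl group, and none gives a readable size, so no step beyond the scatter is expected in this assay. The expected step of a number no higher from compound 3 to compound 4 (the limit leaves the size open) is accordingly small. Compound 4 is estimated at 100000 nM, with a range from 40000 nM to 300000 nM, and is expected most likely to come back as a limit once more.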

Compound 4, half-maximal inhibitory concentration: > 100000 nM
Compound 4: no number, only a limit (the forecaster's own chance of this, stated with the estimate: 80%); the middle value lies on the limit itself.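

No step involving compound 4 can be read against compound 1, compound 2 or compound 3 in this assay, because all four stand at the same limit: the limit of > 100000 nM in this assay, at which 4 of the 4 values shown sit.

The compounds shown leave open what size any change on the amide-type nitrogen has in this assay.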